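Notes on replacing 2,3-dihydroxypropoxy with 3-carboxypropoxy

A few compounds are considered here, and "the series" means these few. Any claim that something is new, unique, unknown or untested is made for them only; others in the source may bear on it.

- compound 1 `COc1cc(C2CN(C(=O)c3cc(OC[C@H](O)CO)ccn3)C2)ccc1OCc1ccc(C2CC2)cc1`: 64%
- compound 2 `COc1cc(C2CN(C(=O)c3cc(OC[C@@H](O)CO)ccn3)C2)ccc1OCc1ccc(C2CC2)cc1`: 63%

Both values come from an ADME assay on S9 fraction from liver (Homo sapiens) for metabolic stability, read by LC-MS, using NADPH, with stated times of 5 min and 60 min, tested at 5 uM; a higher number here means that more of the compound is left, a lower number that less of the compound is left. Among the compounds with values here, compound 2 stands level with compound 1, and the only measured step is a number 1 percentage points lower from compound 1 to compound 2 (within the scatter). That step says little about the next change because of the fact that compounds 1 and 2 differ only in the configuration as drawn.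

Compound 3 `COc1cc(C2CN(C(=O)c3cc(OCCCC(=O)O)ccn3)C2)ccc1OCc1ccc(C2CC2)cc1` keeps the shared core and alters the chain: 2-carboxyethyl in place of 1,2-dihydroxyethyl on a saturated chain carbon bound to an oxygen on an aromatic ring. Here 2-carboxyethyl stands in place of 1,2-dihydroxyethyl on a saturated chain carbon bound to an oxygen on an aromatic ring. Within the data shown here, no measured step covers a change of this kind, so the data give no direction and only weakly bound its size. The working anchor is therefore compound 2 at 63%, with no step beyond the scatter expected in this assay, though with low confidence. The estimated change is a number 2 percentage points higher from compound 2 to compound 3 (within the scatter). The estimate for compound 3 is 65%, with the value expected between 45% and 85%.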

Compound 3, percent of the compound remaining: 91%
Compound 3: the middle estimate sits 26 percentage points below what was measured, outside the stated range (above it).
By their numbers in this assay, from the lowest: compounds 2 and 1 (each within the scatter of the next); then compound 3.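

In this assay, the place on a saturated chain carbon bound to an oxygen on an aromatic ring proves sensitive to the identity of the group it carries: with 2-carboxyethyl in place of 1,2-dihydroxyethyl, the result is a number 28 percentage points higher from compound 2 to compound 3 (beyond the scatter), and likewise a number 27 percentage points higher from compound 1 to compound 3 (beyond the scatter). The earlier pair showed no response to a change of drawn configuration in the chain, whereas this change of group gives a step beyond the scatter. The two steps amount to one comparison seen from two nearly identical starting points, because of what separates those starting points: the fact that compounds 1 and 2 differ only in the configuration as drawn.

Open, on these data alone, is whether the step follows the entering carboxylic acid, the loss of the hydroxyl groups, or the length of the chain, as the change alters all of these together. A plain propyl chain, a primary amide or a shorter carboxymethyl chain at this place would help to tell these readings apart, and the present compounds do not show whether the same step would hold on a different core.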